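A larger group on the sulfonamide nitrogen

This account rests on a few compounds, and the source may have more. Where it says the series, first, only, none or still open, it means among the compounds named here.

Compound 1 `CC1(C)C=C(n2ccccc2=O)c2cc(S(N)(=O)=O)ccc2O1`: 69.2 nM
Compound 2 `CCNS(=O)(=O)c1ccc2c(c1)C(n1ccccc1=O)=CC(C)(C)O2`: 56.2 nM

Within the data shown here, both compounds were tested in a functional assay with Rattus norvegicus as the target (a lower number here means that less compound is needed, a higher number that more compound is needed for the effect), and compound 2 stands level with the only other number available. Compound 3 `COc1ccc(NS(=O)(=O)c2ccc3c(c2)C(n2ccccc2=O)=CC(C)(C)O3)cc1` has 4-methoxyphenyl in place of ethyl on a sulfonamide nitrogen. Among the measured compounds shown here, the sole guide is a 1.2-fold lower number from compound 1 to compound 2 (0.09 log units; within the scatter), for ethyl in place of hydrogen on a sulfonamide nitrogen. That is a smaller change than this one, so it gives no firm direction, and no step beyond the scatter is expected, though with wide uncertainty. The expected step is a 1.4-fold higher number from compound 2 to compound 3 (0.15 log units; within the scatter). For compound 3 the estimated value is 80 nM, with an expected range of 15 nM to 400 nM.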

Compound 3, half-maximal effective concentration: 117 nM
Compound 3: the middle estimate sits 1.5-fold (0.17 log units) below what was measured; low and high end bracket the measured number.
By their numbers in this assay, from the lowest: compounds 2, 1 and 3 (each within the scatter of the next, the first and the last beyond it).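

In this assay, among these compounds, 4-methoxyphenyl on the sulfonamide nitrogen gives a 2.1-fold higher number from compound 2 to compound 3 (0.32 log units; beyond the scatter), the first step in this set beyond the scatter and a modest one, while measured against the unsubstituted sulfonamide it gives a 1.7-fold higher number from compound 1 to compound 3 (0.23 log units; within the scatter). A group with an aromatic ring can therefore sit on this nitrogen with only a small shift in the number, and whether that shift exceeds the scatter depends on the comparison compound. Nothing available explains the shift. The compounds shown leave open how a plain phenyl, a benzyl or a longer chain such as butyl would read at this nitrogen.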